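Moving Nitrogen and Methyl Within a Pyridyl Substituent

The source may report more compounds than this note shows. Statements on the series, on what has been measured and on what is new or still open speak of the compounds shown alone.

Compound 1 `Cc1ccccc1-c1cc(F)cc(-n2nnc(-c3ccccn3)n2)c1` gives 23 nM in an assay for binding affinity to metabotropic glutamate receptor 5 (Rattus norvegicus); on this read-out lower numbers stand for stronger inhibition and higher numbers for weaker inhibition.
Compound 2 `Fc1cc(-c2ccccn2)cc(-n2nnc(-c3ccccn3)n2)c1` gives 95 nM in this assay.
Compound 3 `Cc1ncccc1-c1cc(F)cc(-n2nnc(-c3ccccn3)n2)c1` gives 45 nM in this assay.

Among these three numbers compound 3 stands second highest. Its nearest neighbour is compound 1, and that step, a 2.0-fold higher number from compound 1 to compound 3 (0.29 log units; within the scatter), stays within the usual scatter, so the two cannot be ranked. Compound 2 lies further off: a 2.1-fold lower number from compound 2 to compound 3 (0.32 log units; beyond the scatter).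

Compound 4 `Cc1ccncc1-c1cc(F)cc(-n2nnc(-c3ccccn3)n2)c1` has not yet been measured. It differs from compound 3 in one place: 4-methylpyridin-3-yl in place of 2-methylpyridin-3-yl on an aromatic carbon. Both measured steps that touch this position bear on the change. One, a 2.0-fold higher number from compound 1 to compound 3 (0.29 log units; within the scatter), is within the scatter; the other, a 2.1-fold lower number from compound 2 to compound 3 (0.32 log units; beyond the scatter), is modest. Compound 4 keeps the same atoms as compound 3, only rearranged, so a step in this assay of no more than modest size is expected, in either direction, most likely none beyond the scatter. Compound 4 is therefore estimated at 55 nM, with a range from 20 nM to 150 nM. That estimate corresponds to an expected step of a 1.2-fold higher number from compound 3 to compound 4 (0.09 log units; within the scatter).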

Compound 4, inhibition constant: 2 nM
Estimate against measurement, compound 4: 28-fold (1.44 log units) above, outside the stated range (below it).
By their numbers in this assay, from the lowest: compound 4; then compounds 1 and 3 (each within the scatter of the next); then compound 2.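

Swapping 2-methylpyridin-3-yl for 4-methylpyridin-3-yl adds and removes no atoms, yet in this assay this rearrangement alone gives a large step (a 23-fold lower number from compound 3 to compound 4 (1.35 log units; beyond the scatter)). Compound 4 also stands well clear of the two other compounds (a 12-fold lower number from compound 1 to compound 4 (1.06 log units; beyond the scatter); a 48-fold lower number from compound 2 to compound 4 (1.68 log units; beyond the scatter)), so at this position the arrangement of atoms within the ring can matter far more than the earlier, smaller steps suggested. Nothing measured here explains why this arrangement gives so low a number.

Going by these compounds, it remains open whether the methyl of 4-methylpyridin-3-yl is needed for this low number, or whether an ethyl, a methoxy or a chloro group would serve as well. The ring nitrogen raises the same question, since the 4-methylphenyl counterpart does not appear among these compounds.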